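The source may hold more compounds than are shown below. What is called first, only, known or untested is meant among the compounds shown, and "the series" means these compounds.

Working notes on the series.

Two of the three measured compounds sit at a limit of a functional assay on A2780 cells (Homo sapiens) for inhibition, read by MTT assay, with a stated time of 48 h; on this read-out lower numbers stand for stronger inhibition and higher numbers for weaker inhibition. Compound 1 `C/C=C\C[C@@H](C)C[C@@H](C)/C(O)=C1/C(=O)N/C(=C\c2ccc(O)cc2)C1=O` reaches only a limit, and in this assay compound 1 gives > 40000 nM. Compound 2 `C/C=C\C[C@H](C)C[C@H](C)/C(O)=C1/C(=O)N/C(=C\c2ccc(O)cc2)C1=O` likewise reaches only a limit, and in this assay compound 2 gives > 40000 nM. These two compounds have the same atoms and bonds and differ only in configuration as drawn, and the step that the two limits leave unreadable from compound 1 to compound 2 cannot be read because the limit of > 40000 nM in this assay, at which 2 of the 3 values shown sit, and the fact that compounds 1 and 2 differ only in the configuration as drawn leave no number on either side. Within the data shown here, compound 3 `C=C[C@@H]1C[C@H](C)C[C@H](C)C1c1c(O)ccn(O)c1=O`, built on a different core, is the only compound with a number: in this assay compound 3 gives 1360 nM, and compound 3 stands as the one readable point.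

Compound 4 `C=C[C@@H]1C[C@H](C)C[C@H](C)C1c1c(O)cc[nH]c1=O` is the next member. It differs from compound 3 by hydrogen in place of hydroxy on an aromatic nitrogen. No measured step touches this change: the only step shown, between compounds 1 and 2, is unreadable and concerns configuration alone on another core. The expected step from compound 3 to compound 4 is therefore set with wide margins, a 2.9-fold higher number from compound 3 to compound 4 (0.47 log units; beyond the scatter), and the estimate for compound 4 in this assay is 4000 nM, with a range from 1000 nM to 30000 nM.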

Compound 4, half-maximal inhibitory concentration: > 40000 nM
Compound 4 ended at the assay's limit; the forecaster's own chance of this, stated with the estimate: 25%; middle value at least 10-fold (1.00 log units) away from the limit.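

In this assay compound 4 reaches only a limit, > 40000 nM, and this value is not a number. Hydrogen in place of hydroxy on the aromatic nitrogen gives an at least 29-fold higher number from compound 3 to compound 4 (1.46 log units; beyond the scatter), the first readable step in the series and the first to show that this position matters: among these two compounds, the measurable inhibition goes with the hydroxy on the nitrogen, although the data give no reason for this. The step can be given only as a lower bound, and the steps between the compounds at the limit cannot be read, because one side of each has no number: the limit of > 40000 nM in this assay, at which 3 of the 4 values shown sit.

The compounds shown leave open whether a methoxy group, an amino group or a methyl group on this aromatic nitrogen would keep a readable number like that of compound 3, or whether the hydroxy alone does so. They also leave open whether a hydroxy group on a ring nitrogen would have any comparable effect in a series built on the core of compound 1.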